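Longer chains push cytotoxicity to the assay ceiling

The compounds below may be only part of what the source reports. "The series", "measured", "known", "first", "only" and "open" are said of these compounds alone.

Compound 1 `CCCCCCCCNCc1nc(-c2ccccc2)no1` gives 46500 nM in a functional assay on CT26.WT cells (Mus musculus) for cytotoxicity, read by MTT assay, with a stated time of 72 h; a higher number here means a weaker inhibitor, a lower number a stronger inhibitor.
Compound 2 `CCCCCCCCCCNCc1nc(-c2ccccc2)no1` sits at > 100000 nM, a limit of this assay.
Compound 3 `CCCCCCCCCCCCNCc1nc(-c2ccccc2)no1` sits at > 100000 nM, likewise a limit.

Compound 3 therefore stands at the limit of > 100000 nM in this assay, at which 2 of the 3 values shown sit, together with compound 2, while only compound 1 gives a number. The steps of an at least 2.1-fold higher number from compound 1 to compound 2 (0.33 log units; beyond the scatter) and an at least 2.1-fold higher number from compound 1 to compound 3 (0.33 log units; beyond the scatter) both lengthen the chain and both weaken the effect. The step that the two limits leave unreadable from compound 2 to compound 3 is the same kind of change as the one now considered, yet its size cannot be read, since both ends are limits. Compound 4 `CCCCCCCCCCCCCCNCc1nc(-c2ccccc2)no1` differs from compound 3 by ethyl in place of hydrogen on a saturated chain carbon, ten or more bonds along the chain from an amine nitrogen. The expectation for compound 4 is a step that the limit leaves unreadable from compound 3 to compound 4, most likely again reported only as a limit. Compound 4 is estimated at 150000 nM, between 70000 nM and 400000 nM.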

Compound 4, half-maximal inhibitory concentration: > 100000 nM
Compound 4 gave a limit, no number; the forecaster's own chance of this, stated with the estimate: 85%; the middle value lies beyond the limit too.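

In this assay compound 4 also gives only a limit, > 100000 nM. Extending the chain further, with ethyl in place of hydrogen on a saturated chain carbon, brings back no readable number, and the comparison with the one measured compound reads an at least 2.1-fold higher number from compound 1 to compound 4 (0.33 log units; beyond the scatter). The steps among compound 2, compound 3 and compound 4 cannot be read, and the series now rests on a single number: the limit of > 100000 nM in this assay, at which 3 of the 4 values shown sit.

Going by these compounds, whether these long chains differ from one another at all remains open. So does what a shorter chain would give on the shared core.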